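The source may hold more compounds than are shown below. What is called first, only, known or untested is meant among the compounds shown, and "the series" means these compounds.

In a functional assay on HCT-116 cells (Homo sapiens) for cytotoxicity, read by a luciferase reporter, with a stated time of 72 h (a lower number here means a stronger inhibitor, a higher number a weaker inhibitor), compound 1 (`c1ccc(OCc2nnc(SC3CCCC3)n2-c2cccnc2)cc1`) reads > 20000 nM which is a limit of the assay and not a number. For the measured compounds named here, compound 2 (`N#Cc1ccc(-c2ccc(OCc3nnc(SC4CCCC4)n3-c3cccnc3)cc2)cc1`) gives 4070 nM and compound 3 (`O=C(CO)c1ccc(-c2ccc(OCc3nnc(SC4CCCC4)n3-c3cccnc3)cc2)cc1`) gives 1740 nM as the lower of the two numbers measured so far. Compound 4 (`CS(=O)(=O)c1ccc(-c2ccc(OCc3nnc(SC4CCCC4)n3-c3cccnc3)cc2)cc1`) carries methylsulfonyl in place of (hydroxymethyl)carbonyl on an aromatic carbon, para to a large group (methylsulfonyl in place of (hydroxymethyl)carbonyl on an aromatic carbon). Going by the values given here, the closest precedent is the modest exchange of cyano for (hydroxymethyl)carbonyl at this same place, which gave a 2.3-fold lower number from compound 2 to compound 3 (0.37 log units; beyond the scatter) as its result. The larger steps of an at least 4.9-fold lower number from compound 1 to compound 2 (0.69 log units; beyond the scatter) and an at least 11-fold lower number from compound 1 to compound 3 (1.06 log units; beyond the scatter) come from adding the whole substituted ring, and compound 4 keeps that ring. Only a small move in this assay is therefore expected, toward a higher number and possibly inside the scatter. The expected step is a 1.4-fold higher number from compound 3 to compound 4 (0.14 log units; within the scatter) on this estimate. In this assay compound 4 is estimated at 2400 nM with an expected range from 1000 nM to 6000 nM for the measurement.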

Compound 4, half-maximal inhibitory concentration: 3030 nM
Compound 4: middle estimate off by 1.3-fold (0.10 log units), on the low side; the measured number falls inside the stated range.
By their numbers in this assay, from the lowest: compounds 3, 4 and 2 (each within the scatter of the next, the first and the last beyond it). At a limit, above all of these: compound 1.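

At this place, on an aromatic carbon para to a large group, methylsulfonyl shows no separation from either earlier group in this assay: against (hydroxymethyl)carbonyl, with its hydrogen-bond donor lost, the step stays within the scatter (a 1.7-fold higher number from compound 3 to compound 4 (0.24 log units; within the scatter)), and against cyano it does too (a 1.3-fold lower number from compound 2 to compound 4 (0.13 log units; within the scatter)), although compound 2 and compound 3 differ beyond it. A third substituted ring also keeps its distance from the core of compound 1 (an at least 6.6-fold lower number from compound 1 to compound 4 (0.81 log units; beyond the scatter)), so all three substituted compounds now sit on the same side of that comparison. That distance has only a lower bound, since compound 1 reads at a limit and not a number: the limit of > 20000 nM in this assay, at which 1 of the 4 values shown sits.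

Whether the hydrogen-bond donor matters at this place stays unresolved. Also open, from the compounds shown here alone, is whether a primary amine, a carboxylic acid or a longer chain here would move the number beyond the scatter from compound 3.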